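Benzyl Variants on a Shared Nucleoside Core at the Limit

This account rests on a few compounds, and the source may have more. Where it says the series, first, only, none or still open, it means among the compounds named here.

Compound 1 `OC[C@H]1O[C@@H](n2cnc3c(NCc4ccccc4F)ncnc32)[C@H](O)[C@@H]1O` — a limit only: > 166000 nM
Compound 2 `OC[C@H]1O[C@@H](n2cnc3c(NCc4cccc(Br)c4)ncnc32)[C@H](O)[C@@H]1O` — a limit only: > 166000 nM
Compound 3 `OC[C@H]1O[C@@H](n2cnc3c(NCc4ccc(F)cc4Cl)ncnc32)[C@H](O)[C@@H]1O` — a limit only: > 166000 nM

In a functional assay on MCF cells (Homo sapiens) for antiproliferative activity, with a stated time of 72 h (a higher number here means a weaker inhibitor, a lower number a stronger inhibitor), compound 2 stands at a limit, as do the other two, which is what the limit of > 166000 nM in this assay, at which 3 of the 3 values shown sit, records. The steps a step that the two limits leave unreadable from compound 1 to compound 2 and a step that the two limits leave unreadable from compound 2 to compound 3 are therefore unreadable, and neither bears any readable size on the change to compound 4 `OC[C@H]1O[C@@H](n2cnc3c(NCc4cc(O)cc(O)c4)ncnc32)[C@H](O)[C@@H]1O`. That change is 3,5-dihydroxyphenyl in place of 3-bromophenyl on a saturated chain carbon bound to a nitrogen on an aromatic ring. With every measured step hidden by the limit, no step beyond the scatter can be read in either direction, and compound 4 is expected to remain at or near the same limit. The step that the limit leaves unreadable from compound 2 to compound 4 is thus the expected one. Compound 4 is estimated at 200000 nM, within 80000 nM to 500000 nM.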

Compound 4, half-maximal inhibitory concentration: > 166000 nM
Compound 4 was reported as a limit; the forecaster's own chance of this, stated with the estimate: 85%; the middle value does not contradict the limit.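

Compound 4 sits at the same limit as compound 1, compound 2 and compound 3, so no step to compound 4 can be read: the limit of > 166000 nM in this assay, at which 4 of the 4 values shown sit.

As far as these compounds go, whether any benzyl variant on the shared core gives a readable value in this assay stays open.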